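This account rests on a few compounds, and the source may have more. Where it says the series, first, only, none or still open, it means among the compounds named here.

The series shares the core of compound 1 `Cc1csc(N)c1C(=O)c1ccc(Cl)cc1`. In an assay on CHO cells for displacement of a labelled ligand from adenosine receptor A3 (Homo sapiens), read by scintillation counting, tested at 10 uM (on this read-out lower numbers stand for less inhibition and higher numbers for more inhibition at the one concentration tested (going by the name of the read-out)), compound 1 gives 1%. Compound 2 `CC(C)(C)c1csc(N)c1C(=O)c1ccc(Cl)cc1` gives 1% in this assay, and compound 3 `Cc1c(-c2ccccc2)sc(N)c1C(=O)c1ccc(Cl)cc1` gives 1%. The step of no change at the digits printed from compound 1 to compound 2 (within the scatter) and the step of no change at the digits printed from compound 1 to compound 3 (within the scatter) both stay within the scatter, so compound 3 stands level with compound 1 and compound 2 on the numbers shown. Compound 4 `COc1ccc(-c2sc(N)c(C(=O)c3ccc(Cl)cc3)c2C)cc1` differs from compound 3 by methoxy in place of hydrogen on an aromatic carbon. Within the data shown here, no measured step bears on a methoxy group; the two flat steps at hand are the only guide, and nothing in them points away from the floor. The expected step of a number 1 percentage points higher from compound 3 to compound 4 (within the scatter) is therefore none beyond the scatter. For compound 4 the estimate in this assay is 2%, with a range from -8% to 12%.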

Compound 4, a percentage reported as inhibition, at one concentration (the size of the read-out at that concentration, not a potency): 1%
Estimate against measurement, compound 4: 1 percentage points above, and the stated range covers the measured number.
By their numbers in this assay, from the lowest: compounds 1, 2, 3 and 4 (each within the scatter of the next).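

In this assay, among these compounds, phenyl to 4-methoxyphenyl reads as no change at the digits printed from compound 3 to compound 4 (within the scatter) and so shows that methoxy, the first substituent on the added phenyl, does not lift the series off the level of the earlier compounds. Hydrogen to the whole 4-methoxyphenyl group reads as no change at the digits printed from compound 1 to compound 4 (within the scatter) and so shows that the larger group leaves the read-out just as flat. No evidence is at hand on why the read-out stays flat.

From the compounds shown here alone, whether an amine or a carboxylic acid in place of methoxy would move the read-out remains open. So does whether any group at this position can raise the inhibition beyond the scatter.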